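This account rests on a few compounds, and the source may have more. Where it says the series, first, only, none or still open, it means among the compounds named here.

Values measured in a functional assay on PC-3 cells (Homo sapiens) for cytotoxicity, read by WST assay, with a stated time of 72 h; on this read-out higher numbers stand for weaker inhibition and lower numbers for stronger inhibition:

- compound 1 `O=C1Nc2c(ccc(F)c2F)C1(c1ccc(O)cc1)c1cccnc1`: > 1000 nM (a limit)
- compound 2 `O=C1Nc2c(ccc(F)c2F)C1(CC1CCCCC1)c1ccc(O)cc1`: > 1000 nM (a limit)

Neither compound gives an actual number, as the shared ceiling shows: the limit of > 1000 nM in this assay, at which 2 of the 2 values shown sit. Compound 2 stands only at a limit, > 1000 nM, not at a measured potency.

Compound 3 `O=C1Nc2c(ccc(F)c2F)C1(Cc1ccccc1)c1ccc(O)cc1` keeps the shared core and alters one group of compound 2: phenyl in place of cyclohexyl on a saturated chain carbon bound to a saturated ring carbon. Phenyl takes the place of cyclohexyl on a saturated chain carbon bound to a saturated ring carbon, so cyclohexylmethyl becomes benzyl.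

Among the measured compounds shown here, the one measured step that bears on this change is a step that the two limits leave unreadable from compound 1 to compound 2. It has no readable size, so it offers no guide to how large the new step will be or which way it will go.

Compound 2 is held at the limit > 1000 nM, so the expectation for compound 3 is a result close to that limit, quite possibly another limit, with no direction favoured.

The estimated step, with wide uncertainty, is a step that the limit leaves unreadable from compound 2 to compound 3.

For compound 3 the expected value in this assay is about 1500 nM, with an estimated range from 250 nM to 5000 nM.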

Compound 3, half-maximal inhibitory concentration: > 1000 nM
Compound 3: no number, only a limit; the forecaster's own chance of this, stated with the estimate: 65%; the middle value does not contradict the limit.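

Compound 3 gives > 1000 nM in this assay, which is a limit and not a number. Among the compounds shown here, no step among compound 1, compound 2 and compound 3 can be read, because all three stop at the same ceiling: the limit of > 1000 nM in this assay, at which 3 of the 3 values shown sit. Going by these compounds, what stays open is how potent each compound actually is, and whether pyridin-3-yl, cyclohexylmethyl or benzyl makes any difference.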